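The source may report more compounds than this note shows. Statements on the series, on what has been measured and on what is new or still open speak of the compounds shown alone.

In a functional assay on HT-29 cells (Homo sapiens) for inhibition (on this read-out lower numbers stand for stronger inhibition of growth and higher numbers for weaker inhibition of growth), compound 1 `C/C=C/C=C/C(=O)C[C@H](CCO)OC` gives 49000 nM and compound 2 `C/C=C/C=C/C(=O)CC(CCO)OCC[C@H](O)CC(=O)CC/C=C/C` gives 28000 nM, so these two values lie within the usual scatter of each other. Compound 3 `C/C=C/C=C/C(=O)CC(CCO)OCC[C@H](O)CC(=O)/C=C/C=C/C` differs from compound 2 in one place: on a carbonyl carbon, penta-1,3-dien-1-yl stands in place of pent-3-en-1-yl (penta-1,3-dien-1-yl in place of pent-3-en-1-yl on a carbonyl carbon). Going by the values given here, no measured pair shows this change on its own. Only a small shift toward stronger inhibition, not clearly beyond the scatter, is expected in this assay. The expected move is a 1.4-fold lower number from compound 2 to compound 3 (0.15 log units; within the scatter). For compound 3 the estimated value is 20000 nM, with a range of 7000 nM to 50000 nM.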

Compound 3, concentration for 50% growth inhibition: 29000 nM
Compound 3: the middle estimate sits 1.5-fold (0.16 log units) below what was measured; measured number inside the range.
By their numbers in this assay, from the lowest: compounds 2, 3 and 1 (each within the scatter of the next).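

In this assay, penta-1,3-dien-1-yl in place of pent-3-en-1-yl on a carbonyl carbon reads as a 1.0-fold higher number from compound 2 to compound 3 (0.02 log units; within the scatter), so at this place a chain with one double bond and a chain with two read alike within the scatter. Going by these compounds alone, no earlier pair showed this change on its own. Nothing available here offers an explanation for this result. Still open, on these data alone, is whether a saturated pentyl chain, a longer chain, an amine or a carboxylic acid at this place would give a clearly different number.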